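Fluoro at the chloro position: expectation for compound 4

This account rests on a few compounds, and the source may have more. Where it says the series, first, only, none or still open, it means among the compounds named here.

The series shares one core; compound 1 is `COc1ccc(/C=C/C=C/C(=O)c2cc(Cl)ccc2O)cc1`, compound 2 is `COc1ccc(/C=C/C=C/C(=O)c2ccccc2O)cc1` and compound 3 is `O=C(/C=C/C=C/c1ccccc1)c1ccccc1O`. In an in vitro assay on cells for inhibition of Amine oxidase [flavin-containing] B (Homo sapiens), read by Amplex Red, with a stated time of 15 min (a higher number here means a weaker inhibitor, a lower number a stronger inhibitor), compound 1 gives 153 nM, compound 2 gives 1810 nM and compound 3 gives 106 nM. Compound 2 stands highest of the three, since the step of a 12-fold higher number from compound 1 to compound 2 (1.07 log units; beyond the scatter) and the step of a 17-fold lower number from compound 2 to compound 3 (1.23 log units; beyond the scatter) both lie beyond the scatter. The unmeasured compound 4, `COc1ccc(/C=C/C=C/C(=O)c2cc(F)ccc2O)cc1`, differs from compound 2 by fluoro in place of hydrogen on an aromatic carbon — fluoro in place of hydrogen on an aromatic carbon, the same aromatic carbon that bears chloro in compound 1. The step that bears on it is a 12-fold higher number from compound 1 to compound 2 (1.07 log units; beyond the scatter): taking chloro off that carbon raised the number by a large margin, so placing fluoro there is expected to lower it. Only compound 1 and compound 2 speak to this carbon, so the size is uncertain. The step from compound 2 to compound 4 is expected to be a 3.6-fold lower number from compound 2 to compound 4 (0.56 log units; beyond the scatter). Compound 4 is estimated at 500 nM in this assay, within the range 150 nM to 1800 nM.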

Compound 4, half-maximal inhibitory concentration: 726 nM
Compound 4: middle estimate off by 1.5-fold (0.16 log units), on the low side; measured number inside the range.
By their numbers in this assay, from the lowest: compounds 3 and 1 (each within the scatter of the next); then compound 4; then compound 2.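

Fluoro on the aromatic carbon para to a hydroxy group also lowers the number in this assay, with a 2.5-fold lower number from compound 2 to compound 4 (0.40 log units; beyond the scatter), so the gain at this position is not confined to chloro. The identity of the substituent still matters, since a 4.7-fold higher number from compound 1 to compound 4 (0.68 log units; beyond the scatter), and fluoro therefore captures only part of the change seen in a 12-fold higher number from compound 1 to compound 2 (1.07 log units; beyond the scatter). No measurement available here accounts for the difference between fluoro and chloro at this carbon.

Going by these compounds, whether bromo, methyl or an amine on this carbon would continue the trend, or give a number lower than that of compound 1, remains open. Also open, on these data alone, is whether fluoro or chloro here would lower the number on the core of compound 3, which has hydrogen in place of methoxy.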